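The compounds below may be only part of what the source reports. "The series", "measured", "known", "first", "only" and "open" are said of these compounds alone.

In a functional assay for inhibition, with Rattus norvegicus as the target (on this read-out lower numbers stand for stronger inhibition and higher numbers for weaker inhibition), compound 1 (`CCCCc1c(CCCC)c(OC(C)=O)c2ccccc2c1OC`) gives 6020 nM and compound 2 (`CCc1c(CC)c(OC(C)=O)c2ccccc2c1OC`) gives 400 nM on the same scale. Compound 3 (`CCCCc1cc(OC)c2ccccc2c1O`) gives 1470 nM as the second highest of the three numbers, with gaps beyond the scatter to both others. Compound 4 (`CCCCc1cc(OC)c2ccccc2c1OC`) carries methyl in place of hydrogen on an oxygen on an aromatic ring, which turns hydroxy to methoxy. Among the measured compounds shown here, no measured pair isolates this change. Compound 2 also lacks a free hydroxy and still reads 400 nM in this assay and therefore only a moderate rise in the number, meaning somewhat weaker inhibition, is expected. The expected move is a 1.7-fold higher number from compound 3 to compound 4 (0.23 log units; within the scatter) and may stay near the scatter. For compound 4 the estimated value is 2500 nM (range 700 nM to 9000 nM).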

Compound 4, half-maximal inhibitory concentration: 40900 nM
The estimate for compound 4 lay 16-fold (1.21 log units) below the measured number; the whole stated range lies below it.
By their numbers in this assay, from the lowest: compound 2; then compound 3; then compound 1; then compound 4.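

In this assay the change from hydroxy to methoxy on this oxygen proves far from minor: methyl in place of hydrogen gives a 28-fold higher number from compound 3 to compound 4 (1.44 log units; beyond the scatter) and so a large weakening of inhibition. Among the compounds shown here, it is the first measured pair to isolate this position, and it shows that the read-out is highly sensitive to this single replacement. Nothing measured here accounts for the size of this step. The compounds shown leave open how an ethoxy group on this oxygen, or an amine in place of the hydroxy, would read.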